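Naphthalenyl Replaces Methylphenyl at the Sulfonyl Sulfur

The source may hold more compounds than are shown below. What is called first, only, known or untested is meant among the compounds shown, and "the series" means these compounds.

Compound 2 `Cc1cccc(S(=O)(=O)NCc2ccc(CNC(=O)c3ccccc3C)cc2)c1` gives 1000 nM in an assay on MDA-MB-231 cells for displacement of a labelled ligand from C-X-C chemokine receptor type 4 (Homo sapiens), read by fluorescence and microscopy, with stated times of 10 min and 30 min (on this read-out lower numbers stand for an effect already at smaller amounts and higher numbers for an effect only at larger amounts of compound), the highest of the two numbers measured, while compound 1 `Cc1ccccc1C(=O)NCc1ccc(CNS(=O)(=O)c2ccccc2C)cc1` gives 10 nM. Within the data shown here, the one step that bears on the sulfonyl sulfur, a 100-fold higher number from compound 1 to compound 2 (2.00 log units; beyond the scatter), was large, so a large step is expected again at this position. Compound 3 `Cc1ccccc1C(=O)NCc1ccc(CNS(=O)(=O)c2cccc3ccccc23)cc1` differs from compound 2 by naphthalen-1-yl in place of 3-methylphenyl on a sulfonyl sulfur. With the 3-methylphenyl that gave the higher number leaving, a lower number is expected, as the step of a 25-fold lower number from compound 2 to compound 3 (1.40 log units; beyond the scatter). Compound 3 is therefore estimated at 40 nM, with a range from 5 nM to 400 nM.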

Compound 3, effective concentration (reported as EC, without a stated level of effect): 100 nM
Estimate against measurement, compound 3: 2.5-fold (0.40 log units) below, within the range that was stated.
By their numbers in this assay, from the lowest: compound 1; then compound 3; then compound 2.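

In this assay, the sulfonyl sulfur proves able to carry a larger aromatic group than a methylphenyl, since naphthalen-1-yl gives a 10-fold lower number from compound 2 to compound 3 (1.00 log units; beyond the scatter) and so recovers part of what the 3-methylphenyl lost. It still does not reach the 2-methylphenyl, with a 10-fold higher number from compound 1 to compound 3 (1.00 log units; beyond the scatter) as the remaining gap, so the number here does not follow group size alone. Nothing available accounts for this order. Still open, going by these compounds, is how this position responds to a sulfonyl group bearing an amine, a carboxylic acid or a longer chain instead of an aromatic ring.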